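Naphthyl pyridine acids and amides against CDK8

The source may report more compounds than this note shows. Statements on the series, on what has been measured and on what is new or still open speak of the compounds shown alone.

Measured compounds:
compound 1, `O=C(O)CCc1ccncc1-c1ccc2ccccc2c1`: 101%
compound 2, `O=C(CCc1ccncc1-c1ccc2ccccc2c1)N1CCOCC1`: 100%
compound 3, `NC(=O)/C=C/c1ccncc1Nc1ccc(F)cc1`: 70%

In an assay on a protein complex for inhibition of CDK8/Cyclin C (Homo sapiens), with a stated time of 1 h, tested at 10 uM (a lower number here means less inhibition, a higher number more inhibition at the concentration tested (going by the name of the read-out)), compound 1 gives 101%, the highest of the three numbers shown. Compound 2 stands within the scatter of it, and compound 3 lies beyond the scatter below both. For the measured compounds named here, the one step between measured compounds that differ in one place is a number 1 percentage points lower from compound 1 to compound 2 (within the scatter), morpholin-4-yl in place of hydroxy on a carbonyl carbon; it changes nothing beyond the scatter.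

Compound 4, `CN(C)C(=O)/C=C/c1ccncc1-c1ccc2ccccc2c1`, has not yet been measured. Its difference from compound 1 is 2-(dimethylcarbamoyl)ethenyl in place of 2-carboxyethyl on an aromatic carbon. Going by the values given here, this change touches the same side chain as the step from compound 1 to compound 2, which was within the scatter, so a comparable outcome in this assay is the expectation, with no step beyond the scatter foreseen, though compound 4 adds a second double bond outside aromatic rings and loses the hydrogen-bond donor, for which no measured step exists. The expected step is a number 6 percentage points lower from compound 1 to compound 4 (within the scatter). For compound 4 the estimate is 95%, in the range 80% to 104%.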

Compound 4, a percentage reported as inhibition, at one concentration (the size of the read-out at that concentration, not a potency): 100%
Beside the measured number, compound 4's estimate is 5 percentage points below it; measured number inside the range.
By their numbers in this assay, from the lowest: compound 3; then compounds 2, 4 and 1 (each within the scatter of the next).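

In this assay, the position on the aromatic carbon opposite the ring nitrogen takes 2-(dimethylcarbamoyl)ethenyl in place of 2-carboxyethyl, giving a number 1 percentage points lower from compound 1 to compound 4 (within the scatter). Where the earlier step altered only the group on the carbonyl carbon, this change also alters the chain itself, bringing in a second double bond outside aromatic rings, and the read-out stays within the scatter. No supporting measurement bears on this result.

The read-out comes from one concentration, and at that concentration no stronger or weaker effect can be told among compound 1, compound 2 and compound 4. Also open, as far as these compounds go, is whether this position would hold up with an amine or a longer chain, and the lower value of compound 3 cannot be assigned to any single change.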